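Moving the hydroxyl around a phenyl ring

A few compounds are considered here, and "the series" means these few. Any claim that something is new, unique, unknown or untested is made for them only; others in the source may bear on it.

Within the data shown here, compound 2 `Oc1cccc(-c2cc(-c3cccs3)cc(-c3ccccc3O)n2)c1` is the one compound here with a measured number: in a functional assay on DU-145 cells (Homo sapiens) for cytotoxicity, read by CCK-8 assay (a higher number here means a weaker inhibitor, a lower number a stronger inhibitor), compound 2 gives 9300 nM. Its companion compound 1 `Oc1ccccc1-c1cc(-c2cccs2)cc(-c2ccccc2O)n1` carries two 2-hydroxyphenyl groups. In this assay compound 1 gives only a limit, > 50000 nM, and not a number (the limit of > 50000 nM in this assay, at which 1 of the 2 values shown sits). Among the measured compounds shown here, the single measured step, an at least 5.3-fold lower number from compound 1 to compound 2 (0.73 log units; beyond the scatter), shows that shifting the hydroxyl to a different position on that phenyl ring already changes the outcome.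

Compound 3 `Oc1ccc(-c2cc(-c3cccs3)cc(-c3ccccc3O)n2)cc1` has not been measured. It differs from compound 2 by 4-hydroxyphenyl in place of 3-hydroxyphenyl on an aromatic carbon; the two compounds hold the same atoms, joined differently, so the change is once more a move of the hydroxyl around the phenyl ring. For the measured compounds named here, no measured step covers this particular move; the step from compound 1 to compound 2 bears on it only by showing that such moves can matter. With no closer guide, compound 3 is expected to sit near compound 2. Compound 3 is therefore expected to move only modestly, a step of a 1.6-fold lower number from compound 2 to compound 3 (0.19 log units; within the scatter). In this assay compound 3 is estimated at 6000 nM, within a range from 1500 nM to 25000 nM.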

Compound 3, half-maximal inhibitory concentration: > 50000 nM
Compound 3: a limit, no number (the forecaster's own chance of this, stated with the estimate: 15%); at least 8.3-fold (0.92 log units) between middle value and limit.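

The 4-hydroxyphenyl group does not behave like the 3-hydroxyphenyl group on this carbon next to the ring nitrogen: in this assay, this further move of the hydroxyl gives an at least 5.3-fold higher number from compound 2 to compound 3 (0.73 log units; beyond the scatter). Compound 1 and compound 2 alone could only show that one move away from the 2-hydroxyphenyl group changed the outcome, whereas compound 2 now stands apart from both of its neighbours, so among these three compounds a measured number appears only with the hydroxyl in the 3-hydroxyphenyl arrangement. Among these compounds, the step between compound 1 and compound 3 cannot be read, since each of the two gives a limit and not a number, which leaves compound 2 as the only true measurement in the set: the limit of > 50000 nM in this assay, at which 2 of the 3 values shown sit.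

Still open, as far as these compounds go, is whether a different group on this same phenyl ring, such as an amine or a carboxylic acid in place of the hydroxyl, would keep, improve or lose the number seen for compound 2. The compounds shown also leave open how much the second 2-hydroxyphenyl group and the thiophen-2-yl group contribute, as both stay the same throughout.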